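A few compounds are considered here, and "the series" means these few. Any claim that something is new, unique, unknown or untested is made for them only; others in the source may bear on it.

In a functional assay on U-87MG ATCC cells for antiproliferative activity against U-87 MG (Homo sapiens), read by MTT assay, with a stated time of 48 h, tested at 100 uM (a lower number here means a stronger effect, a higher number a weaker effect of the compound at the concentration tested), three compounds that share one core have been measured. Compound 1 `Cc1nc(-c2ccc(Cl)cc2)sc1C(=O)CSc1nc(-c2ccccc2)c(C#N)c(=O)[nH]1` gives 11.4%, compound 2 `Cc1nc(-c2ccc(Cl)cc2)sc1C(=O)CSc1nc(-c2cccc(Cl)c2)c(C#N)c(=O)[nH]1` gives 12.5%, and compound 3 `COc1ccc(-c2nc(SCC(=O)c3sc(-c4ccc(Cl)cc4)nc3C)[nH]c(=O)c2C#N)cc1OC` gives 18.7%, the highest of the three numbers, although a number 7.3 percentage points higher from compound 1 to compound 3 (within the scatter) and a number 6.2 percentage points higher from compound 2 to compound 3 (within the scatter), so all three stand close together. Compound 4 `Cc1nc(-c2ccc(Cl)cc2)sc1C(=O)CSc1nc(-c2ccc(Cl)cc2)c(C#N)c(=O)[nH]1` differs from compound 3 in one place: 4-chlorophenyl in place of 3,4-dimethoxyphenyl on an aromatic carbon. For the measured compounds named here, two measured steps bear on this change. At the same place, a number 1.1 percentage points higher from compound 1 to compound 2 (within the scatter), and the reverse of the change in hand is a number 6.2 percentage points higher from compound 2 to compound 3 (within the scatter). A step back toward the numbers of compounds 1 and 2 is therefore expected, and the step estimated for compound 4 is a number 5.7 percentage points lower from compound 3 to compound 4 (within the scatter). Compound 4 is expected to give about 13%, within a range from 7% to 20%.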

Compound 4, a percentage reported as activity, at one concentration (the size of the read-out at that concentration, not a potency): 12.8%
For compound 4 the middle estimate is 0.2 percentage points above the measured one; the measured number falls inside the stated range.
By their numbers in this assay, from the lowest: compounds 1, 2, 4 and 3 (each within the scatter of the next).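

On this aromatic carbon of the shared core, in this assay, replacing 3,4-dimethoxyphenyl with 4-chlorophenyl gives only a small step (a number 5.9 percentage points lower from compound 3 to compound 4 (within the scatter)). Moving the chloro around the phenyl ring also makes no readable difference, as 4-chlorophenyl against 3-chlorophenyl shows (a number 0.3 percentage points higher from compound 2 to compound 4 (within the scatter)), and neither does adding it to plain phenyl (a number 1.4 percentage points higher from compound 1 to compound 4 (within the scatter)). No measurement here explains these steps. As far as these compounds go, all four groups at this place are substituted or plain phenyl rings, so it stays open whether an amine, a carboxylic acid or a longer chain there would give a step beyond the scatter.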